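Moving the Ring Nitrogen in a Receptor Inhibitor Series

The source may report more compounds than this note shows. Statements on the series, on what has been measured and on what is new or still open speak of the compounds shown alone.

Measured so far:
Compound 1, `COCCn1c(SCc2cc([N+](=O)[O-])ccc2OC)nc2cc(NC(=O)NC(C)(C)C)ccc21`: 57 nM
Compound 2, `COc1ccc([N+](=O)[O-])cc1CSc1nc2cc(NC(=O)NC(C)(C)C)ccc2n1Cc1cccnc1`: 33 nM

Both compounds were tested in an assay on isolated protein for inhibition of Gonadotropin-releasing hormone receptor (Homo sapiens); on this read-out higher numbers stand for weaker inhibition and lower numbers for stronger inhibition. Compound 2 holds the lowest of the two numbers in this assay, but its nearest neighbour, compound 1, differs from it only by a 1.7-fold lower number from compound 1 to compound 2 (0.24 log units; within the scatter), so the two are not separated by more than the usual scatter. For the measured compounds named here, that single step, the replacement of a methoxymethyl group by a pyridin-3-yl group on a saturated chain carbon bound to an aromatic nitrogen, is the only comparison available.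

Compound 3, `COc1ccc([N+](=O)[O-])cc1CSc1nc2cc(NC(=O)NC(C)(C)C)ccc2n1Cc1ccncc1`, has not yet been tested. It differs from compound 2 by pyridin-4-yl in place of pyridin-3-yl on a saturated chain carbon bound to an aromatic nitrogen. Going by the values given here, no measured step touches this kind of change, since the one known step swapped a whole group rather than shifting the nitrogen within a ring. Among the compounds with values here, with the only available step lying within the scatter and nothing speaking for a shift in either direction, the expectation for compound 3 in this assay is a step of about a 1.1-fold higher number from compound 2 to compound 3 (0.03 log units; within the scatter), that is, no change beyond the scatter. Compound 3 is therefore estimated at 35 nM, within a range of 12 nM to 100 nM.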

Compound 3, half-maximal inhibitory concentration: 47 nM
Estimate against measurement, compound 3: 1.3-fold (0.13 log units) below, within the range that was stated.
By their numbers in this assay, from the lowest: compounds 2, 3 and 1 (each within the scatter of the next).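

Compound 3 tests something the earlier pair could not: the same ring stays on the same carbon and only its nitrogen sits elsewhere, pyridin-4-yl in place of pyridin-3-yl on a saturated chain carbon bound to an aromatic nitrogen, and in this assay this gives a 1.4-fold higher number from compound 2 to compound 3 (0.15 log units; within the scatter), so the two pyridine forms cannot be told apart on this read-out. The comparison with the non-aromatic group now has a second reading, pyridin-4-yl in place of methoxymethyl, which gives a 1.2-fold lower number from compound 1 to compound 3 (0.08 log units; within the scatter), so neither pyridine form can be separated from methoxymethyl at this place, and all three compounds shown sit within the scatter of one another. Nothing measured alongside these numbers speaks to why they lie so close together.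

Still open, on these data alone, is whether any group at this place would give a number clearly apart from these three, for example pyridin-2-yl, a plain phenyl ring, an amine or a carboxylic acid on a longer chain. Also open, as far as these compounds go, is whether the position of the ring nitrogen would matter more if the rest of the molecule were different.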